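A few compounds are considered here, and "the series" means these few. Any claim that something is new, unique, unknown or untested is made for them only; others in the source may bear on it.

Measured compounds so far:

- compound 1, `CN1CCN(CCCOc2c(OCc3ccccc3)cc(O)c3c(=O)cc(-c4ccccc4)oc23)CC1`; in a functional assay on A549 cells (Homo sapiens) for cytotoxicity, read by MTT assay, with a stated time of 72 h (a higher number here means a weaker inhibitor, a lower number a stronger inhibitor), compound 1 gives 3940 nM
- compound 2, `Cc1ccc(COc2cc(O)c3c(=O)cc(-c4ccccc4)oc3c2OCCCCN2CCN(C)CC2)cc1`; in this assay compound 2 gives 3200 nM

Compound 2 carries the lower of the two numbers, but compound 1 lies within the scatter of it, so the two count as indistinguishable and no ranking is drawn. They differ from each other in more than one place, so no single step can be read off between them; the pair only shows that both sit in the same low-micromolar region of this assay.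

Compound 3, `CN1CCN(CCCCOc2c(OCc3cccs3)cc(O)c3c(=O)cc(-c4ccccc4)oc23)CC1`, is the next entry, not yet run in this assay. It departs from compound 2 in one place: thiophen-2-yl in place of 4-methylphenyl on a saturated chain carbon bound to an oxygen on an aromatic ring. Among the compounds with values here, no measured step of this kind exists, so the expectation rests on the change alone. A swap of one aromatic ring for another at the same position, with the rest of the molecule untouched, is expected to move the number little, if at all beyond the scatter, with a slight lean towards a weaker value; the step from compound 2 to compound 3 is estimated at a 1.3-fold higher number from compound 2 to compound 3 (0.10 log units; within the scatter). For compound 3 the estimate in this assay is 4000 nM, with a range of 1800 nM to 9000 nM.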

Compound 3, half-maximal inhibitory concentration: 2100 nM
The estimate for compound 3 lay 1.9-fold (0.28 log units) above the measured number; low and high end bracket the measured number.
By their numbers in this assay, from the lowest: compounds 3, 2 and 1 (each within the scatter of the next).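

Within the data shown here, this is the first step that can be read at a single place. On a saturated chain carbon bound to an oxygen on an aromatic ring, thiophen-2-yl in place of 4-methylphenyl gives a 1.5-fold lower number from compound 2 to compound 3 (0.18 log units; within the scatter) in this assay. At this position, then, a six-membered aromatic ring of carbon only and a five-membered aromatic ring with a hetero atom cannot be told apart in this read-out, and the exchange of the smaller thiophen-2-yl for 4-methylphenyl brings no change beyond the scatter. No measurement of any property of these groups accompanies this step, and the result stands without an explanation.

Among these compounds, compound 1 differs from both other compounds in more than one place, so no step to it can be read, and the effect of the second chain on the shared core remains unresolved. Also open, from the compounds shown here alone, is whether a group of a different kind at this position, such as a pyridin-2-yl ring, a 4-carboxyphenyl ring or a 4-aminophenyl ring, would move the number beyond the scatter.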